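Aminoaryl changes on the sulfonamide and rat exposure

This account rests on a few compounds, and the source may have more. Where it says the series, first, only, none or still open, it means among the compounds named here.

Measured in an ADME assay on the whole organism (plasma) for pharmacokinetics, with Rattus norvegicus as the target, with a stated time of 6 h, at a dose of 10 mg/kg by the oral route; on this read-out lower numbers stand for lower exposure and higher numbers for higher exposure at the dose given:
compound 1 `Cc1ccc(CNS(=O)(=O)N2CCN(/C(C=N)=C(\OCC3(C)CC3)C(=O)Nc3cccc(Cl)c3)CC2)cc1N`: 1410 ng.h/mL
compound 2 `CC1(CO/C(C(=O)Nc2cccc(Cl)c2)=C(/C=N)N2CCN(S(=O)(=O)NCc3ccnc(N)c3)CC2)CC1`: 50 ng.h/mL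
compound 3 `COc1cc(CNS(=O)(=O)N2CCN(/C(C=N)=C(\OCC3(C)CC3)C(=O)Nc3cccc(Cl)c3)CC2)ccc1N`: 860 ng.h/mL

Compound 2 stands lowest of the three numbers in this assay. Its nearest neighbour is compound 3, reached by a 17-fold higher number from compound 2 to compound 3 (1.24 log units; beyond the scatter), and compound 1 lies furthest off, as shown by a 28-fold lower number from compound 1 to compound 2 (1.45 log units; beyond the scatter). Compound 1 and compound 3 sit close to each other, with a 1.6-fold lower number from compound 1 to compound 3 (0.21 log units; within the scatter).

The unmeasured compound 4 `CC(NS(=O)(=O)N1CCN(/C(C=N)=C(\OCC2(C)CC2)C(=O)Nc2cccc(Cl)c2)CC1)c1cccc(N)c1` follows from compound 2 by a single change: 1-(3-aminophenyl)ethyl in place of (2-aminopyridin-4-yl)methyl on a sulfonamide nitrogen. Going by the values given here, the steps that bear on it are the two already seen at this position, in which the 2-aminopyridin-4-yl ring gives way to a six-membered aromatic ring of carbon only carrying an amino group: a 17-fold higher number from compound 2 to compound 3 (1.24 log units; beyond the scatter) and, read backwards, a 28-fold lower number from compound 1 to compound 2 (1.45 log units; beyond the scatter). Both were large and both point the same way. Compound 4 carries a ring of that carbon-only kind, but the 1-(3-aminophenyl)ethyl group has not itself been measured in this assay, so the size of its effect is uncertain. The account therefore expects a large rise in this assay, estimated as a 12-fold higher number from compound 2 to compound 4 (1.08 log units; beyond the scatter). Compound 4 is estimated at 600 ng.h/mL in this assay, with a range from 150 ng.h/mL to 2400 ng.h/mL.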

Compound 4, area under the concentration-time curve: 1300 ng.h/mL
For compound 4 the middle estimate is 2.2-fold (0.34 log units) below the measured one; the range from low to high includes it.
By their numbers in this assay, from the lowest: compound 2; then compounds 3, 4 and 1 (each within the scatter of the next).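

In this assay, the third ring of carbon only at this position again stands far from the 2-aminopyridin-4-yl ring, with a 26-fold higher number from compound 2 to compound 4 (1.41 log units; beyond the scatter), and this holds even though 1-(3-aminophenyl)ethyl also differs from the earlier benzyl groups on the chain carbon and in the ring groups. Compound 4 cannot be separated from the other two carbon-only compounds, with a 1.5-fold higher number from compound 3 to compound 4 (0.18 log units; within the scatter) and a 1.1-fold lower number from compound 1 to compound 4 (0.04 log units; within the scatter), so among compounds 1, 3 and 4 the sulfonamide nitrogen accepts the 1-(3-aminophenyl)ethyl, 3-amino-4-methylbenzyl and 4-amino-3-methoxybenzyl groups with no difference that can be read in this measure. No measurement given here explains why compound 2 stands apart from the three carbon-only compounds.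

The compounds shown leave open whether the plain 3-aminobenzyl group would stand with compounds 1, 3 and 4, and whether a 1-(2-aminopyridin-4-yl)ethyl group would stay as low as compound 2. They also leave open whether the amino group on the ring matters at all, since an unsubstituted benzyl group or a hydroxyl in place of the amino group does not appear among them.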